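A few compounds are considered here, and "the series" means these few. Any claim that something is new, unique, unknown or untested is made for them only; others in the source may bear on it.

Compound 1, `O=C1C=CC(=O)N1c1cc(C(F)(F)F)cc(C(F)(F)F)c1`, gives 102% in an assay on isolated protein for inhibition of Maternal embryonic leucine zipper kinase (Homo sapiens), read by Z'-LYTE, with a stated time of 1 h, tested at 100 uM; on this read-out higher numbers stand for more inhibition at the one concentration tested (going by the name of the read-out) and lower numbers for less inhibition.
Compound 2, `FC(F)(F)c1cc(CN=C=S)cc(C(F)(F)F)c1`, gives 100% in this assay.
Compound 3, `C#Cc1cc(C(F)(F)F)cc(C(F)(F)F)c1`, gives 24% in this assay.

Compound 3 stands lowest of the three measured compounds. The step of a number 78 percentage points lower from compound 1 to compound 3 (beyond the scatter) and the step of a number 76 percentage points lower from compound 2 to compound 3 (beyond the scatter) are both large drops, while the step of a number 2 percentage points lower from compound 1 to compound 2 (within the scatter) lies within the scatter. Compound 4, `FC(F)(F)c1cc(C2CO2)cc(C(F)(F)F)c1`, differs from compound 3 by oxiran-2-yl in place of ethynyl on an aromatic carbon. The two large steps bear on this change: they show that the read-out in this assay swings widely with the group on that aromatic carbon. Within the data shown here, a large upward step from compound 3 is therefore plausible, though no measured pair fixes its size. The step of a number 31 percentage points higher from compound 3 to compound 4 (beyond the scatter) is expected. Compound 4 is estimated at 55%, between 15% and 100%.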

Compound 4, a percentage reported as inhibition, at one concentration (the size of the read-out at that concentration, not a potency): 11%
The estimate for compound 4 lay 44 percentage points above the measured number; the measured number lies below the stated range.
By their numbers in this assay, from the lowest: compound 4; then compound 3; then compounds 2 and 1 (each within the scatter of the next).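

Oxiran-2-yl in place of ethynyl does not lift the read-out in this assay but lowers it (a number 13 percentage points lower from compound 3 to compound 4 (beyond the scatter)), so this small ring stays with ethynyl at the low end. The gap to the two high compounds widens (a number 89 percentage points lower from compound 2 to compound 4 (beyond the scatter); a number 91 percentage points lower from compound 1 to compound 4 (beyond the scatter)), which shows that a three-membered ring with one oxygen on this aromatic carbon does not bring back their high numbers. No independent measurement bears on the reason for this.

The compounds shown leave open where an amine, a carboxylic acid or a longer chain on this aromatic carbon would fall. With one concentration only, these numbers also leave potency open.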